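Replacing the oxime-bearing arm of compound 1 with acetyl

The source may report more compounds than this note shows. Statements on the series, on what has been measured and on what is new or still open speak of the compounds shown alone.

Measured compounds:
- compound 1, `C/C(=N\O)c1ccc(NC(=O)Cn2nc(-c3ccc(Cl)cc3)nc2N)cc1`: 33%
- compound 2, `COc1cc(-c2nc(N)n(CC(=O)Nc3ccc(/C(C)=N\O)cc3)n2)cc(OC)c1OC`: 8.41%

Of the compounds shown here, two sharing a common core have been tested in a functional assay on MOLT-4 cells (Homo sapiens) for inhibition, read by sulforhodamine B assay, with a stated time of 48 h, tested at 10 uM; a lower number here means less inhibition of growth, a higher number more inhibition of growth at the concentration tested. Compound 1 gives the higher of the two numbers, 33%, and compound 2, which carries three methoxy groups on its pendant aromatic ring instead of a single chlorine, gives 8.41%. The gap between them lies beyond the usual scatter, so compound 1 stands clearly above compound 2 on the numbers available.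

Compound 3, `CC(=O)c1ccc(NC(=O)Cn2nc(-c3ccc(Cl)cc3)nc2N)cc1`, has not yet been measured in this assay. It keeps the chlorine-bearing ring of compound 1 and differs only at the far end of the molecule: a group of 3 heavy atoms (2 carbon, 1 oxygen; no ring) in place of a group of 4 heavy atoms (2 carbon, 1 nitrogen, 1 oxygen; no ring), on an aromatic carbon. Going by the values given here, with no directly comparable pair among the measured compounds, the size of this step can only be guessed. A modest loss of growth inhibition is expected, of a size near the edge of the scatter, a number 8 percentage points lower from compound 1 to compound 3 (within the scatter). Compound 3 is therefore estimated to give 25% in this assay, within a range from 5% to 45%.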

Compound 3, percent growth inhibition at one concentration: 16.5%
Beside the measured number, compound 3's estimate is 8.5 percentage points above it; the range from low to high includes it.
By their numbers in this assay, from the lowest: compounds 2 and 3 (each within the scatter of the next); then compound 1.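

Going by these compounds alone, this step is the first that isolates a single position: on an aromatic carbon of a six-membered aromatic ring of carbon only, para to a large group, with the chlorine-bearing ring left in place, putting acetyl in place of the oxime-bearing arm gives a number 16.5 percentage points lower from compound 1 to compound 3 (beyond the scatter) in this assay. Growth inhibition at the concentration tested therefore depends on what sits at this position, a point the earlier pair could not show, since compound 1 and compound 2 differ at the pendant aromatic ring and not here. The change takes the group from 1 hydrogen-bond donor and 2 hydrogen-bond acceptors to 0 hydrogen-bond donors and 1 hydrogen-bond acceptor, but no measurement shown here connects that difference to the loss in growth inhibition.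

The compounds shown leave open how other groups at this position, such as an amine, a carboxylic acid or a longer chain, would compare with the oxime-bearing arm and with acetyl. They also leave open whether the same exchange would have a similar effect with the three methoxy groups of compound 2 on the pendant aromatic ring.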